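A Morpholine Urea Swap on a Chemokine Receptor Binder

The compounds below may be only part of what the source reports. "The series", "measured", "known", "first", "only" and "open" are said of these compounds alone.

Compound 3 `Cc1ccccc1C(=O)Nc1ccc(S(=O)(=O)NC2CCN(C(=O)CN)CC2)c2ccccc12` gives 4.1 nM in an assay on L1.2 cells for binding affinity to C-C chemokine receptor type 8 (Homo sapiens) (on this read-out lower numbers stand for stronger inhibition and higher numbers for weaker inhibition), the lowest of the two numbers available. Compound 1 `CCOC(=O)N1CCC(NS(=O)(=O)c2ccc(C(=O)Nc3ccccc3C)c3ccccc23)CC1` gives 5.21 nM in this assay, a figure within the scatter of compound 3. Compound 2 `CCOC(=O)N1CCC(NS(=O)(=O)c2ccc(O)c3ccccc23)CC1` reaches only a limit in this assay, namely > 5000 nM (the limit of > 5000 nM in this assay, at which 1 of the 3 values shown sits). Going by the values given here, the single measured step, an at least 950-fold higher number from compound 1 to compound 2 (2.98 log units; beyond the scatter), concerns another part of the shared core and does not bear on the change now considered. Compound 4 `Cc1ccccc1C(=O)Nc1ccc(S(=O)(=O)NC2CCN(C(=O)N3CCOCC3)CC2)c2ccccc12` differs from compound 3 by morpholin-4-yl in place of aminomethyl on a carbonyl carbon. Compound 1 and compound 3 already carry different groups on the carbonyl carbon yet sit within the scatter of each other, so no step beyond the scatter is expected: a 1.2-fold higher number from compound 3 to compound 4 (0.09 log units; within the scatter). Compound 4 is therefore estimated at 5 nM, between 2 nM and 15 nM.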

Compound 4, inhibition constant: 6.3 nM
Beside the measured number, compound 4's estimate is 1.3-fold (0.10 log units) below it; low and high end bracket the measured number.
By their numbers in this assay, from the lowest: compounds 3, 1 and 4 (each within the scatter of the next). At a limit, above all of these: compound 2.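

On a carbonyl carbon, morpholin-4-yl in place of aminomethyl gives a 1.5-fold higher number from compound 3 to compound 4 (0.19 log units; within the scatter) in this assay. This position therefore accepts a six-membered non-aromatic ring as well as the smaller open group. The hydrogen-bond donor of aminomethyl can also go without a step beyond the scatter. Nothing shown here explains this result. Going by these compounds, whether a carboxylic acid, a phenyl ring or a longer chain on this carbonyl carbon would keep the number in the same range remains open.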